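The source may hold more compounds than are shown below. What is called first, only, known or untested is meant among the compounds shown, and "the series" means these compounds.

Compound 1 `O=C(Nc1ccc(Sc2nc3ccccc3s2)c(Cl)c1)c1ccccc1O` is the starting point of this step. In an assay for inhibition of HSP60/HSP10 (Homo sapiens), with a stated time of 60 min (a lower number here means a stronger inhibitor, a higher number a weaker inhibitor), compound 1 gives > 100000 nM, which is a limit of the assay and not a number. Compound 2 `O=C(Nc1ccc(Sc2nc3ccccc3s2)cc1)c1ccccc1O` also reaches only a limit in this assay, > 100000 nM. Among the measured compounds shown here, the one measured step, a step that the two limits leave unreadable from compound 1 to compound 2, joins two values that both sit at the limit of > 100000 nM in this assay, at which 2 of the 3 values shown sit, so its size stays hidden. For the measured compounds named here, compound 3 `O=C(Nc1ccccc1)c1cc(Br)cc(Br)c1O` is the only member with a number in this assay, where compound 3 gives 63000 nM. Compound 4 `COc1c(Br)cc(Br)cc1C(=O)Nc1ccc(Sc2nc3ccccc3s2)c(Cl)c1` is not yet measured; it differs from compound 1 by a group of 10 heavy atoms (7 carbon, 1 oxygen, 2 bromine; one six-membered aromatic ring of carbon only) in place of a group of 7 heavy atoms (6 carbon, 1 oxygen; one six-membered aromatic ring of carbon only), on a carbonyl carbon. Going by the values given here, no measured step covers this change, and the single step available is unreadable. Compound 3 carries two bromines on its benzamide ring and does reach a number, but with a different amide partner and a different oxygen group, so it fixes no size. The step from compound 1 to compound 4 is therefore expected to be a number no higher from compound 1 to compound 4 (the limit leaves the size open), not readable as gain or loss from a limit. Compound 4 is expected to give about 100000 nM in this assay, within 30000 nM to 300000 nM, with a fair chance that only a limit is reported again.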

Compound 4, half-maximal inhibitory concentration: > 100000 nM
Compound 4 gave a limit, no number; the forecaster's own chance of this, stated with the estimate: 60%; the middle value lies on the limit itself.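

No step can be read between compound 1 and compound 4. In this assay compound 4 gives > 100000 nM, which is a limit and not a number: the limit of > 100000 nM in this assay, at which 3 of the 4 values shown sit.

The compounds shown leave open how far the group on the carbonyl carbon changes inhibition on the core of compound 1.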